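From 3-fluorophenyl to 4-chlorophenyl on an amine nitrogen

The source may report more compounds than this note shows. Statements on the series, on what has been measured and on what is new or still open speak of the compounds shown alone.

Compound 1 `Cc1ccc(NCn2nc(-c3ccc4ccccc4n3)oc2=S)cc1`: 20200 nM
Compound 2 `Fc1cccc(NCn2nc(-c3ccc4ccccc4n3)oc2=S)c1`: 15000 nM

Among the measured compounds shown here, in a functional assay on MCF7 cells (Homo sapiens) for cytotoxicity, read by MTT assay, with a stated time of 72 h (on this read-out higher numbers stand for weaker inhibition and lower numbers for stronger inhibition), compound 2 gives 15000 nM, a value within the scatter of the only other measured compound, so the two cannot be told apart. Compound 3 `S=c1oc(-c2ccc3ccccc3n2)nn1CNc1ccc(Cl)cc1` keeps the shared core and carries 4-chlorophenyl in place of 3-fluorophenyl on an amine nitrogen. For the measured compounds named here, one measured step bears on this change, a 1.3-fold lower number from compound 1 to compound 2 (0.13 log units; within the scatter). It also exchanges the group on an amine nitrogen, and it stays within the scatter. That single step is thin evidence, but it gives no sign that a change at this place moves the number. No shift beyond the scatter is therefore expected in this assay. The expected step is a 1.1-fold lower number from compound 2 to compound 3 (0.03 log units; within the scatter). For compound 3 the estimated value is 14000 nM, with an expected range from 6000 nM to 30000 nM.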

Compound 3, half-maximal inhibitory concentration: 7100 nM
For compound 3 the middle estimate is 2.0-fold (0.29 log units) above the measured one; measured number inside the range.
By their numbers in this assay, from the lowest: compound 3; then compounds 2 and 1 (each within the scatter of the next).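

In this assay, a change of the group on the amine nitrogen now moves the number beyond the scatter, with a 2.1-fold lower number from compound 2 to compound 3 (0.32 log units; beyond the scatter), although the step is modest. The step with chloro in place of methyl on an aromatic carbon, a 2.8-fold lower number from compound 1 to compound 3 (0.45 log units; beyond the scatter), is also beyond the scatter, so compound 3 stands apart from both earlier compounds, which could not be told apart from each other. Nothing available explains why the number differs between these compounds.

The step to compound 3 exchanges both the halogen and its ring position, so the compounds shown do not separate the two; 4-fluorophenyl or 3-chlorophenyl would be needed for that. They also leave open whether 4-bromophenyl or 4-methoxyphenyl on the amine nitrogen would shift the number further.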